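The compounds below may be only part of what the source reports. "The series", "measured", "known", "first", "only" and "open" are said of these compounds alone.

Measured in a functional assay on Vero cells (Chlorocebus sabaeus) for inhibition; a lower number here means a stronger inhibitor, a higher number a weaker inhibitor:
- compound 1 `COc1cc(/C=C/C(=O)c2cccc(NC(=O)c3ccc(Cl)cc3)c2)ccc1O`: 3.82 ug/mL
- compound 2 `CCOC(=O)C(=O)Nc1cccc(C(=O)/C=C/c2ccc(O)c(OC)c2)c1`: > 50 ug/mL (a limit)

Compound 2 has only a limit and no number: the limit of > 50 ug/mL in this assay, at which 1 of the 2 values shown sits. Compound 3 `COc1cc(/C=C/C(=O)c2cccc(NC(C)=O)c2)ccc1O` keeps the shared core and carries methyl in place of ethoxycarbonyl on a carbonyl carbon. For the measured compounds named here, one measured step bears on this carbonyl carbon, and it is large and beyond the scatter: an at least 13-fold higher number from compound 1 to compound 2 (1.11 log units; beyond the scatter). Group changes here can therefore matter, and a move to a lower number, meaning stronger inhibition, is expected. The expected change is an at least 2.0-fold lower number from compound 2 to compound 3 (0.30 log units; that floor lies within the scatter). The estimate for compound 3 is 25 ug/mL, with an expected range of 8 ug/mL to 60 ug/mL.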

Compound 3, half-maximal inhibitory concentration: 14.5 ug/mL
Estimate against measurement, compound 3: 1.7-fold (0.24 log units) above, within the range that was stated.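

On this carbonyl carbon, a group need not be large or carry a ring to give measurable inhibition in this assay: an at least 3.4-fold lower number from compound 2 to compound 3 (0.53 log units; beyond the scatter). Compound 2 gives only a limit, so that step is a minimum: the limit of > 50 ug/mL in this assay, at which 1 of the 3 values shown sits. Methyl still falls short of 4-chlorophenyl, with a 3.8-fold higher number from compound 1 to compound 3 (0.58 log units; beyond the scatter), so the three groups now show a graded response at this position rather than a simple split between active and inactive.

Whether the ring or its chlorine accounts for the advantage of compound 1 remains open, and a plain phenyl would test this. From the compounds shown here alone, how an aminomethyl group or a longer chain such as propyl would compare also remains open.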